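A few compounds are considered here, and "the series" means these few. Any claim that something is new, unique, unknown or untested is made for them only; others in the source may bear on it.

The series shares one core, shown first as compound 1 `CCN(C(=O)c1cc(C)ccc1-n1nccn1)[C@@H](C)Cn1nnc(-c2ccc(F)cn2)n1` and then as compound 2 `CCN(C(=O)c1cc(C)ccc1-n1nccn1)[C@@H](C)Cn1nnc(-c2ccc(F)cc2)n1`. In a functional assay on cells for antagonist activity at Orexin receptor type 2 (Homo sapiens), read by fluorescence and calcium flux, with a stated time of 30 min (a higher number here means a weaker inhibitor, a lower number a stronger inhibitor), compound 1 gives 17.9 nM, while compound 2 gives 2.57 nM. Among the measured compounds shown here, the only step recorded so far, a 7.0-fold lower number from compound 1 to compound 2 (0.84 log units; beyond the scatter), exchanges the aryl group on the tetrazole and leaves the rest of the molecule untouched. Among the two numbers known, compound 2 stands at the lower end, with compound 1 as its nearest neighbour at a clearly higher number.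

Compound 3 `CCN(C(=O)c1cc(F)ccc1-n1nccn1)[C@@H](C)Cn1nnc(-c2ccc(F)cc2)n1` has not yet been measured. For the measured compounds named here, it differs from compound 2 by fluoro in place of methyl on an aromatic carbon, a change on the benzamide ring that no measured pair in this set addresses. Going by the values given here, the one step available concerns a different region of the molecule, so it offers no direct guide to the size or direction of the present change. In the absence of any relevant step, the number for compound 3 is expected to lie close to that of compound 2, with the step of a 1.2-fold higher number from compound 2 to compound 3 (0.10 log units; within the scatter) expected to fall within the usual scatter. On that basis compound 3 is estimated at 3.2 nM, within a range from 1 nM to 10 nM.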

Compound 3, half-maximal inhibitory concentration: 139 nM
For compound 3 the middle estimate is 43-fold (1.64 log units) below the measured one; measured number outside the range, above it.
By their numbers in this assay, from the lowest: compound 2; then compound 1; then compound 3.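

In this assay, fluoro in place of methyl on the aromatic carbon para to the 2H-1,2,3-triazol-2-yl group gives a 54-fold higher number from compound 2 to compound 3 (1.73 log units; beyond the scatter), a larger step than the exchange of the aryl group on the tetrazole, a 7.0-fold lower number from compound 1 to compound 2 (0.84 log units; beyond the scatter). This position is therefore far from indifferent to the group it carries, and the number here depends strongly on the choice between these two single-atom substituents. The computed counts do not separate the two groups, as methyl and fluoro each bring one heavy atom, no ring, no hydrogen-bond donors or acceptors and no net charge, and no supporting measurement points to what lies behind the step.

The compounds shown leave open whether the higher number follows from the loss of methyl or the entry of fluoro, and how a plain hydrogen, chloro, ethyl or methoxy on this carbon would stand in this assay. They also leave open whether the same exchange would give a step of similar size with 5-fluoropyridin-2-yl on the tetrazole, the group carried by compound 1.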